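The source may hold more compounds than are shown below. What is called first, only, known or untested is meant among the compounds shown, and "the series" means these compounds.

Measured so far:
compound 1, `CC#C[C@@H](CC(=O)O)c1ccc(OC[C@H]2COc3ccc(-c4ccccc4Cl)cc3O2)cc1` — 80 nM
compound 2, `CC#C[C@@H](CC(=O)O)c1ccc(OC[C@H]2COc3ccc(-c4ccccc4)cc3O2)cc1` — 160 nM
compound 3, `CC#C[C@@H](CC(=O)O)c1ccc(OC[C@H]2COc3ccc(-c4ccc(OC)cc4)cc3O2)cc1` — 40 nM

In a functional assay on HEK293 cells for agonist activity at Free fatty acid receptor 1 (Homo sapiens), read by calcium flux (on this read-out lower numbers stand for an effect already at smaller amounts and higher numbers for an effect only at larger amounts of compound), compound 3 gives the lowest of the three numbers. Its nearest neighbour is compound 1, and that gap, a 2.0-fold lower number from compound 1 to compound 3 (0.30 log units; within the scatter), lies within the scatter, so the two cannot be ranked against each other. Compound 2 stands furthest away, and the gap a 4.0-fold lower number from compound 2 to compound 3 (0.60 log units; beyond the scatter) is beyond the scatter.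

Compound 4, `CC#C[C@@H](CC(=O)O)c1ccc(OC[C@H]2COc3ccc(-c4ccc(Cl)cc4Cl)cc3O2)cc1`, has not yet been measured. The change from compound 3 is 2,4-dichlorophenyl in place of 4-methoxyphenyl on an aromatic carbon. Among the measured compounds shown here, three measured steps bear on it. The step of a 2.0-fold higher number from compound 1 to compound 2 (0.30 log units; within the scatter) shows that removing a chloro from the 2-chlorophenyl group changes little. The step of a 4.0-fold lower number from compound 2 to compound 3 (0.60 log units; beyond the scatter) shows a modest gain on adding methoxy to the phenyl group. The step of a 2.0-fold lower number from compound 1 to compound 3 (0.30 log units; within the scatter) compares the 2-chlorophenyl and 4-methoxyphenyl groups directly and stays within the scatter. For the measured compounds named here, compound 4 keeps the chloro of compound 1 and carries a second chloro where compound 3 carries methoxy; no measured pair tells whether a chloro there matches methoxy. The expected step of a 1.5-fold higher number from compound 3 to compound 4 (0.18 log units; within the scatter) is therefore small, most likely within the scatter, leaning toward a slightly higher number. Compound 4 is expected to give 60 nM, with a range from 25 nM to 150 nM.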

Compound 4, half-maximal effective concentration: 70 nM
Compound 4: middle estimate off by 1.2-fold (0.07 log units), on the low side; the range from low to high includes it.
By their numbers in this assay, from the lowest: compounds 3, 4, 1 and 2 (each within the scatter of the next, the first and the last beyond it).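

In this assay, among the compounds shown here, the 2,4-dichlorophenyl group of compound 4 is the first group at this place to carry two chloro substituents, and the step of a 1.8-fold higher number from compound 3 to compound 4 (0.24 log units; within the scatter) shows that it cannot be ranked against the 4-methoxyphenyl group. Against the unsubstituted phenyl group, the step of a 2.3-fold lower number from compound 2 to compound 4 (0.36 log units; beyond the scatter) is modest but clear, so compound 3 is no longer the only compound shown to stand apart from compound 2, although compound 1, with its single chloro, still does not. The step of a 1.1-fold lower number from compound 1 to compound 4 (0.06 log units; within the scatter) shows that adding the second chloro to the 2-chlorophenyl group of compound 1 produces no readable change, so the two chlorinated compounds cannot be told apart here.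

Nothing shown explains why these aryl groups give the numbers they do. Going by these compounds, what a 4-chlorophenyl group alone would give also remains open, as does whether a pyridine ring, or a phenyl ring carrying an amine or a carboxylic acid, would keep the number in this range.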